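This account rests on a few compounds, and the source may have more. Where it says the series, first, only, none or still open, it means among the compounds named here.

Compound 1 `CC1=C(C(=O)Nc2ccc(Cl)c(Cl)c2)C(c2cccc(O)c2)NC(=S)N1`: 7080 nM
Compound 2 `CC1=C(C(=O)Nc2ccc(F)c(Cl)c2)C(c2cccc(Cl)c2)NC(=S)N1`: 4170 nM
Compound 3 `CC1=C(C(=O)Nc2ccc(F)c(Cl)c2)C(c2cccc(Oc3ccccc3)c2)NC(=S)N1`: 17800 nM

All three were tested in a functional assay on COLO 205 cells (Homo sapiens) for cytotoxicity, read by sulforhodamine B assay, with a stated time of 48 h; a higher number here means a weaker inhibitor of growth, a lower number a stronger inhibitor of growth. Compound 3 gives the highest number of the three: the step of a 4.3-fold higher number from compound 2 to compound 3 (0.63 log units; beyond the scatter) is beyond the scatter, and compound 1 also gives a lower number than compound 3. Compound 4 `CC1=C(C(=O)Nc2ccc(Cl)c(Cl)c2)C(c2cccc(Oc3ccccc3)c2)NC(=S)N1` differs from compound 3 in one place: chloro in place of fluoro on an aromatic carbon. For the measured compounds named here, no measured step isolates this exact change. Going by the values given here, the only measured step, a 4.3-fold higher number from compound 2 to compound 3 (0.63 log units; beyond the scatter), concerns a phenoxy in place of chloro on the other ring and says little about a fluoro-to-chloro swap. Compound 1 gives 7080 nM while compound 2 gives 4170 nM, and these two values lie within the usual scatter of each other even though the two compounds differ in two places at once, one of them being this same fluoro-to-chloro exchange. On that basis the change is expected to move the number little. Compound 4 is therefore expected to land near compound 3, a 1.1-fold lower number from compound 3 to compound 4 (0.05 log units; within the scatter), with an estimate of 16000 nM and a range from 7000 nM to 40000 nM.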

Compound 4, concentration for 50% growth inhibition: 9330 nM
Compound 4: middle estimate off by 1.7-fold (0.23 log units), on the high side; the measured number falls inside the stated range.
By their numbers in this assay, from the lowest: compounds 2, 1, 4 and 3 (each within the scatter of the next, the first and the last beyond it).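

The fluoro-to-chloro exchange, 3-chloro-4-fluorophenyl to 3,4-dichlorophenyl, can now be read directly: in this assay it gives a 1.9-fold lower number from compound 3 to compound 4 (0.28 log units; within the scatter), so with phenoxy on the other ring, this position shows no clear difference between the two halogens. The other ring can also be read with 3,4-dichlorophenyl held constant, where phenyl in place of hydrogen on the oxygen gives a 1.3-fold higher number from compound 1 to compound 4 (0.12 log units; within the scatter), unlike the step with 3-chloro-4-fluorophenyl held constant, a 4.3-fold higher number from compound 2 to compound 3 (0.63 log units; beyond the scatter), which replaces a chloro group rather than a hydrogen. No measurement is available to explain either result.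

On these data alone, whether a nitrile or methoxy group in place of the halogen would move the number beyond the scatter remains open. So does whether fluoro and chloro would still match with an amine on the other ring.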